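A few compounds are considered here, and "the series" means these few. Any claim that something is new, unique, unknown or untested is made for them only; others in the source may bear on it.

Three compounds share one core and differ only in the group attached to one aromatic carbon of that core. Compound 1 `CC(C(=O)NCc1ccc(C(F)(F)F)cc1N1CCC(Cc2ccc(F)cc2)CC1)c1ccc(NS(C)(=O)=O)c(F)c1`, compound 2 `CC(C(=O)NCc1ccc(C(F)(F)F)cc1OC1CCCCC1)c1ccc(NS(C)(=O)=O)c(F)c1` and compound 3 `CCCCCCSc1cc(C(F)(F)F)ccc1CNC(=O)C(C)c1ccc(NS(C)(=O)=O)c(F)c1` each carry a different group there. In an assay on CHO cells for antagonist activity at transient receptor potential cation channel subfamily V member 1 (Homo sapiens), read by FLIPR (on this read-out higher numbers stand for weaker inhibition and lower numbers for stronger inhibition), compound 1 gives 0.4 nM, compound 2 gives 0.7 nM, and compound 3 gives 1.8 nM. Compound 3 stands highest of the three numbers, so it inhibits least strongly of the three. Among the compounds with values here, the single one-place step among the measured compounds is a 2.6-fold higher number from compound 2 to compound 3 (0.41 log units; beyond the scatter), a modest rise but beyond the scatter; the gap between compound 1 and compound 3 is wider still.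

Compound 4 `CC(C(=O)NCc1ccc(C(F)(F)F)cc1-c1ccc(F)c(Cl)c1)c1ccc(NS(C)(=O)=O)c(F)c1` has not yet been measured. It differs from compound 3 in one place: 3-chloro-4-fluorophenyl in place of hexylsulfanyl on an aromatic carbon. Within the data shown here, no measured step puts an aromatic ring at this place, so the size of the change is uncertain. What the numbers do show is that compound 1 and compound 2, which both carry a ring-containing group there, sit at lower numbers than compound 3, whose hexylsulfanyl group has no ring, as the step of a 2.6-fold higher number from compound 2 to compound 3 (0.41 log units; beyond the scatter) records. Compound 4 brings a ring back to this carbon, so a lower number than compound 3 is expected, and the step is estimated as a 2.3-fold lower number from compound 3 to compound 4 (0.35 log units; beyond the scatter). The estimate for compound 4 in this assay is 0.8 nM, with a range from 0.3 nM to 2.5 nM.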

Compound 4, inhibition constant: 0.6 nM
For compound 4 the middle estimate is 1.3-fold (0.12 log units) above the measured one; the range from low to high includes it.
By their numbers in this assay, from the lowest: compounds 1, 4 and 2 (each within the scatter of the next); then compound 3.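

In this assay, within the data shown here, a benzene-type aromatic ring bonded straight to this carbon is accepted: 3-chloro-4-fluorophenyl in place of hexylsulfanyl gives a 3.0-fold lower number from compound 3 to compound 4 (0.48 log units; beyond the scatter), a modest step, and the earlier compounds held no aromatic ring at this place. Set against cyclohexyloxy, the same group gives a 1.2-fold lower number from compound 2 to compound 4 (0.07 log units; within the scatter), so these two quite different ring-bearing groups cannot be told apart on this read-out. Compound 3 is now the only one of the four without a ring in this group and the only one standing apart from the others, although no information here says why the ringless chain gives the higher number.

From the compounds shown here alone, whether the chlorine and the fluorine matter stays open, as it is unknown how a plain phenyl group would compare with 3-chloro-4-fluorophenyl at this carbon. Also open, going by these compounds, is whether a shorter chain than hexylsulfanyl would behave like the longer one, and whether a ring carrying an amine or a carboxylic acid would keep the numbers this low.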